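Adding a second bromine to the aldehyde-derived ring

The compounds below may be only part of what the source reports. "The series", "measured", "known", "first", "only" and "open" are said of these compounds alone.

Measured compounds:
- compound 1, `COc1cc(/C=N/Nc2nc(-c3ccc(Br)cc3)cs2)cc(Br)c1OC`: 52300 nM
- compound 2, `COc1cc(/C=N/Nc2nc(-c3cccc(Br)c3)cs2)cc(Br)c1OC`: 56000 nM
- compound 3, `COc1cc(/C=N/Nc2nc(-c3cc(C(F)(F)F)cc(C(F)(F)F)c3)cs2)cc(Br)c1OC`: 94200 nM

All three were tested in a functional assay on A549 cells (Homo sapiens) for inhibition, read by MTT assay, with a stated time of 48 h (on this read-out higher numbers stand for weaker inhibition and lower numbers for stronger inhibition), and all three gave weak inhibition. Compound 2 stands second highest of the three numbers; its nearest neighbour is compound 1, and compound 3 is the furthest from it, but both of those gaps lie within the scatter, so the three compounds cannot be told apart on these values.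

Compound 4, `COc1cc(/C=N/Nc2nc(-c3cccc(Br)c3)cs2)c(Br)c(Br)c1OC`, differs from compound 2 in one place: bromo in place of hydrogen on an aromatic carbon. The new bromo sits ortho to a bromo group, meta to a methoxy group and para to a methoxy group on the ring that carries the hydrazone.

Within the data shown here, no measured step touches this ring. Among the measured compounds shown here, the only step available, a 1.1-fold higher number from compound 1 to compound 2 (0.03 log units; within the scatter), concerns the other aromatic ring and did not move the number beyond the scatter. There is therefore no basis for expecting a shift in this assay in either direction, and the expected step from compound 2 to compound 4 is essentially none beyond the scatter, a 1.1-fold lower number from compound 2 to compound 4 (0.05 log units; within the scatter).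

Compound 4 is accordingly estimated at 50000 nM, with a plausible range from 20000 nM to 130000 nM.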

Compound 4, half-maximal inhibitory concentration: 37000 nM
Beside the measured number, compound 4's estimate is 1.4-fold (0.13 log units) above it; measured number inside the range.
By their numbers in this assay, from the lowest: compounds 4, 1, 2 and 3 (each within the scatter of the next, the first and the last beyond it).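

Among these compounds, this is the first change on the ring that carries the hydrazone, and in this assay adding the bromo gives a 1.5-fold lower number from compound 2 to compound 4 (0.18 log units; within the scatter). The earlier step concerned only the other aromatic ring, so this result adds a new observation: on this background, a bromo can stand at this aromatic carbon, ortho to a bromo group, meta to a methoxy group and para to a methoxy group, without moving the number beyond the usual scatter, and inhibition remains weak. No measurement available here bears on what lies behind this small step.

From the compounds shown here alone, it remains open whether an amine, a carboxylic acid or a longer chain such as a propoxy group at this same carbon would shift the number beyond the scatter in either direction. Also open, going by these compounds, is whether the added bromo would give a similar step with the 4-bromophenyl group of compound 1 or the two trifluoromethyl groups of compound 3 on the other ring.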